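The source may report more compounds than this note shows. Statements on the series, on what has been measured and on what is new or still open speak of the compounds shown alone.

Liver microsomes are a standard test of how quickly a compound is broken down, and three compounds have been measured in a toxicity assay on microsomes from liver (Homo sapiens) for metabolic stability, read by LC-MS, using NADPH, tested at 1 uM; on this read-out lower numbers stand for slow clearance and higher numbers for fast clearance. Compound 1 `C[C@@H]1CN(c2scnc2-c2nc3ccccc3[nH]2)CCN1C(=O)Cn1cnc2cccnc21` gives 12 mL.min-1.g-1, compound 2 `CCOc1ncc(-c2nc(C(F)(F)F)sc2N2CCN(C(=O)Cn3nccc3C)[C@H](C)C2)cn1` gives 65 mL.min-1.g-1, and compound 3 `Cc1nc(C)n(CC(=O)N2CCN(c3sc(C(F)(F)F)nc3-c3cnc(OC4CCC4)nc3)C[C@H]2C)n1` gives 51 mL.min-1.g-1. Compound 3 therefore stands level with compound 2, within the usual scatter of repeated measurements, and clearly beyond that scatter above compound 1.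

The next compound makes one change. Compound 4 `CCOc1ccc(-c2nc(C(F)(F)F)sc2N2CCN(C(=O)Cn3nc(C)nc3C)[C@H](C)C2)cn1` carries 6-ethoxypyridin-3-yl in place of the 2-(cyclobutyloxy)pyrimidin-5-yl of compound 3, on an aromatic carbon of a five-membered aromatic ring with 1 nitrogen and 1 sulfur (6-ethoxypyridin-3-yl in place of 2-(cyclobutyloxy)pyrimidin-5-yl on an aromatic carbon). For the measured compounds named here, no measured pair here differs in only one place, so the data give no direct precedent for this swap. The closest guide is the pair of values for compound 2 at 65 mL.min-1.g-1 and compound 3 at 51 mL.min-1.g-1, which sit within the scatter of each other, and this supports expecting compound 4 to stay in the same region.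

The expected change is small, an estimated 1.1-fold higher number from compound 3 to compound 4 (0.06 log units; within the scatter), which would lie within the scatter. In this assay, compound 4 is estimated at 58 mL.min-1.g-1, with an expected range of 30 mL.min-1.g-1 to 110 mL.min-1.g-1.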

Compound 4, intrinsic clearance in microsomes: 66 mL.min-1.g-1
For compound 4 the middle estimate is 1.1-fold (0.06 log units) below the measured one, and the stated range covers the measured number.
By their numbers in this assay, from the lowest: compound 1; then compounds 3, 2 and 4 (each within the scatter of the next).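

In this assay the step is a 1.3-fold higher number from compound 3 to compound 4 (0.11 log units; within the scatter) and so, at this aromatic carbon of the five-membered ring with one nitrogen and one sulfur, the read-out does not separate 6-ethoxypyridin-3-yl from 2-(cyclobutyloxy)pyrimidin-5-yl. For the compounds shown here, this is the first pair in the set that differs in only one place, and it shows that this swap leaves the number within the usual scatter, even though the entering group has no four-membered carbon ring, one ring nitrogen fewer and fewer heavy atoms than the group it replaces. The data offer no independent measurement that could explain why the read-out holds steady here.

The swap alters the oxygen-linked chain and the six-membered aromatic ring together, so this pair cannot show what each alteration does alone, or whether the two have opposing effects that happen to cancel. It also leaves open whether clearance would stay in this region with a different kind of group on the six-membered ring, such as a primary amine or a carboxylic acid in place of the ethoxy chain.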